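Shorter Ester Replaces Pyridyl Ester on Triazolopyrimidine Cyclopentane

The source may hold more compounds than are shown below. What is called first, only, known or untested is meant among the compounds shown, and "the series" means these compounds.

Measured compounds:
- compound 1 `CCCSc1nc(N[C@@H]2C[C@H]2c2ccc(F)c(F)c2)c2nnn([C@@H]3C[C@H](OC(C)=O)[C@@H](O)[C@H]3O)c2n1`: "not determined" (no result reported)
- compound 2 `CCCSc1nc(N[C@@H]2C[C@H]2c2ccc(F)c(F)c2)c2nnn([C@@H]3C[C@H](OCCOC(=O)OCC)[C@@H](O)[C@H]3O)c2n1`: 47.7%
- compound 3 `CCCSc1nc(N[C@@H]2C[C@H]2c2ccc(F)c(F)c2)c2nnn([C@@H]3C[C@H](OCCOC(=O)c4cccnc4)[C@@H](O)[C@H]3O)c2n1`: "not active" (no number reported)

Three compounds share one core and differ only in what sits on the oxygen on a saturated carbon of the cyclopentane. In a functional assay on the whole organism (strain Sprague-Dawley) for inhibition, with Rattus norvegicus as the target, with a stated time of 0.5 h, at a dose of 5 mg/kg by the oral route (on this read-out higher numbers stand for more inhibition at the one dose given (going by the name of the read-out) and lower numbers for less inhibition), compound 2 gives 47.7%. Compound 3 was reported in this assay only as "not active" (no number reported), with no number, and compound 1 in this assay stands at "not determined" (no result reported). Compound 3 therefore stands at the bottom of what is known, one of two entries without a figure.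

Compound 4 `CCCSc1nc(N[C@@H]2C[C@H]2c2ccc(F)c(F)c2)c2nnn([C@@H]3C[C@H](OC(=O)OCC(C)C)[C@@H](O)[C@H]3O)c2n1` arises from compound 3 by the change (isobutoxycarbonyl in place of 2-(((pyridin-3-yl)carbonyl)oxy)ethyl on an oxygen on a saturated carbon). The group that enters is small and ringless, resembling in size the acetyl of compound 1, for which no reading exists. Within the data shown here, no measured pair isolates this change, so no step size in this assay can be quoted; the expectation is a number higher than what compound 3 showed, compound 3 being reported in this assay as "not active" (no number reported), while compound 2 with a different chain gave in this assay a mid-range reading of 47.7%.

Compound 4 is estimated in this assay at 30%, in the range 0% to 60%.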

Compound 4, a percentage reported as inhibition, in the whole organism at one dose (the size of the read-out at that dose, not a potency): 13.2%
Estimate against measurement, compound 4: 16.8 percentage points above; the range from low to high includes it.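

With compound 4, a small ringless group on this oxygen gives a reading of 13.2% in this assay, so a figure now stands where the pyridine-bearing chain of compound 3 gave none. Lacking a ring is therefore not enough to fix the reading at this position: the two ringless groups are close in heavy-atom count, yet the step is a number 34.5 percentage points lower from compound 2 to compound 4 (beyond the scatter) and shows that the reading depends strongly on how the chain is built. No measurement offered here explains this drop.

The compounds shown leave open whether a longer chain on the carbonate of compound 4 would move the reading toward that of compound 2. They also leave open how a chain ending in an amine or a carboxylic acid would read at this position.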